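This account rests on a few compounds, and the source may have more. Where it says the series, first, only, none or still open, it means among the compounds named here.

Measured so far:
- compound 1, `COc1ccccc1NC(=S)N1CCc2c(sc(NC(=O)c3ccccc3Cl)c2C(N)=O)C1`: 35200 nM
- compound 2, `NC(=O)c1c(NC(=O)c2ccccc2Cl)sc2c1CCN(C(=S)Nc1ccccc1-c1ccccc1)C2`: 25800 nM

Both compounds share one core and differ only in the aryl group attached to the thiourea nitrogen. In a functional assay on MKN-74 cells (Homo sapiens) for antiproliferative activity, with a stated time of 24 h (on this read-out lower numbers stand for stronger inhibition and higher numbers for weaker inhibition), compound 1 gives 35200 nM, and compound 2 gives 25800 nM. Among the compounds with values here, the single step between them, a 1.4-fold lower number from compound 1 to compound 2 (0.13 log units; within the scatter), is within the scatter, so the two values cannot be ranked against each other. Compound 2 therefore stands lowest of the two numbers, but only by a margin that repeated measurements would not reliably reproduce.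

The next compound, compound 3, `COc1ccc(NC(=S)N2CCc3c(sc(NC(=O)c4ccccc4Cl)c3C(N)=O)C2)cc1`, changes the same aryl group once more: 4-methoxyphenyl in place of 2-phenylphenyl on an amide-type nitrogen. Within the data shown here, the one measured step that bears on this position, from compound 1 to compound 2, is within the scatter, so there is no evidence so far that varying this aryl group moves the read-out in this assay by more than the scatter. The expected step of a 1.2-fold higher number from compound 2 to compound 3 (0.07 log units; within the scatter) is accordingly estimated to be small, with no clear direction. Compound 3 is expected to give about 30000 nM, with a range from 12000 nM to 75000 nM.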

Compound 3, half-maximal inhibitory concentration: 19600 nM
Estimate against measurement, compound 3: 1.5-fold (0.18 log units) above; the range from low to high includes it.
By their numbers in this assay, from the lowest: compounds 3, 2 and 1 (each within the scatter of the next).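

Compound 3 adds two readings at this position on an amide-type nitrogen. In this assay, 4-methoxyphenyl in place of 2-phenylphenyl gives a 1.3-fold lower number from compound 2 to compound 3 (0.12 log units; within the scatter), so going from two six-membered aromatic rings to one, with a hydrogen-bond acceptor entering, leaves the values impossible to rank. The new comparison of the two methoxy-bearing groups, 4-methoxyphenyl in place of 2-methoxyphenyl, gives a 1.8-fold lower number from compound 1 to compound 3 (0.25 log units; within the scatter), so these compounds also show no separable effect of where the methoxy group sits on the ring, and all three aryl groups remain within the scatter of one another; nothing available offers an independent measurement that could explain this closeness.

Every group shown at this position is an aromatic ring of carbon only, so it remains open whether a ring carrying an amine or a carboxylic acid, or a longer carbon chain in place of the ring, would give a value beyond the scatter. The rest of the shared core is identical in all three compounds, so they also leave open how changes elsewhere in the molecule would affect the read-out.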